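The compounds below may be only part of what the source reports. "The series", "measured", "known", "first", "only" and "open" are said of these compounds alone.

In a functional assay on HeLa cells (Homo sapiens) for inhibition (on this read-out lower numbers stand for stronger inhibition and higher numbers for weaker inhibition), three compounds have been measured so far. Compound 1 `Cc1cn(/C=C/C#N)c(=O)[nH]c1=O` gives in this assay only a limit, > 100000 nM, namely (the limit of > 100000 nM in this assay, at which 1 of the 3 values shown sits). Compound 2 `Cc1cn([C@H]2C[C@H](O)[C@@H](CO)O2)c(=O)n(/C=C/C=O)c1=O` gives in this assay 20000 nM. Compound 3 `Cc1cn([C@@H]2O[C@H](CO)[C@@H](O)[C@H]2O)c(=O)n(/C=C/C=O)c1=O` gives in this assay 100000 nM. Compound 2 thus holds the lowest of the two numbers shown; the nearest number stands a 5.0-fold higher number from compound 2 to compound 3 (0.70 log units; beyond the scatter), where a hydroxy replaces hydrogen on a saturated ring carbon.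

Compound 4 `O=C/C=C/n1c(=O)c(I)cn([C@H]2C[C@H](O)[C@@H](CO)O2)c1=O` has not yet been measured in this assay. It differs from compound 2 by iodo in place of methyl on an aromatic carbon. For the measured compounds named here, no measured step concerns a change on the aromatic carbon: the single measured step alters a saturated ring carbon, and the limit of compound 1 belongs to a structure that differs from compound 2 in several places at once. The exchange of methyl for iodo therefore has no measured counterpart among these compounds, and no step beyond the scatter is expected in either direction in this assay. Compound 4 is accordingly expected to give about 20000 nM in this assay, within a range from 5000 nM to 80000 nM. This estimate means an expected step of no change at the digits printed from compound 2 to compound 4 (within the scatter), one that should stay within the scatter.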

Compound 4, half-maximal inhibitory concentration: 80000 nM
For compound 4 the middle estimate is 4.0-fold (0.60 log units) below the measured one, and the stated range covers the measured number.
By their numbers in this assay, from the lowest: compound 2; then compounds 4 and 3 (each within the scatter of the next).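

In this assay, the aromatic carbon that carries the methyl in compound 2 proves sensitive to the group placed there: iodo in place of methyl gives a 4.0-fold higher number from compound 2 to compound 4 (0.60 log units; beyond the scatter). This is the first measured change at this position, and it runs in the same direction as the only earlier step, hydroxy in place of hydrogen on a saturated ring carbon, which gives a 5.0-fold higher number from compound 2 to compound 3 (0.70 log units; beyond the scatter), so each single change shown away from compound 2 raises the number. Nothing measured among these compounds gives a reason for the rise with iodo.

The compounds shown leave open whether the rise belongs to iodo alone or would also appear with other groups on this aromatic carbon, such as a bare hydrogen, chloro, bromo, an ethyl chain or an amine. They also leave open whether the same exchange of methyl for iodo would give a like step with the extra hydroxy of compound 3 present, or with a longer chain in place of the 2-formylethenyl group.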